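Trading one group on compound 2: a clearance estimate

The compounds below may be only part of what the source reports. "The series", "measured", "known", "first", "only" and "open" are said of these compounds alone.

Compound 1 `O=C(O)CCNC(=O)c1ccc(C(Oc2ccc(-n3cc(C(F)(F)F)cn3)cc2)C2CC2)cc1`: < 8 mL/min/kg
Compound 2 `CCCC(Oc1ccc(-n2cc(C(F)(F)F)c(C)n2)cc1)c1ccc(C(=O)NCCC(=O)O)cc1`: < 10 mL/min/kg
Compound 3 `O=C(O)CCNC(=O)c1ccc(C(Oc2ccc(-n3cc(C(F)(F)F)cn3)cc2)C2CCCC2)cc1`: 22 mL/min/kg

All three were tested in an ADME assay on microsomes from liver (Homo sapiens) for metabolic stability; a lower number here means slower removal, a higher number faster removal of the compound. Compound 2 stands at < 10 mL/min/kg, which is a limit and not a number. Compound 1 reports < 8 mL/min/kg, also a limit. Compound 4 `CCCC(Oc1ccc(-n2cc(F)cn2)cc1)c1ccc(C(=O)NCCC(=O)O)cc1` carries 4-fluoro-1H-pyrazol-1-yl in place of 3-methyl-4-(trifluoromethyl)-1H-pyrazol-1-yl on an aromatic carbon. Within the data shown here, the only measured step, an at least 2.7-fold higher number from compound 1 to compound 3 (0.43 log units; beyond the scatter), changes cyclopropyl to cyclopentyl on a saturated chain carbon and leaves this group untouched, so it offers no direct guide. No step beyond the scatter is therefore expected in this assay, and the expected change is a step that the limit leaves unreadable from compound 2 to compound 4. For compound 4 the estimate is 9 mL/min/kg, with an expected range from 4 mL/min/kg to 20 mL/min/kg.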

Compound 4, clearance: 12 mL/min/kg
Compound 4: middle estimate off by 1.3-fold (0.12 log units), on the low side, within the range that was stated.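

Among these compounds, the only step readable before lay on the saturated chain carbon; this one falls on the aromatic carbon, where 4-fluoro-1H-pyrazol-1-yl replaces 3-methyl-4-(trifluoromethyl)-1H-pyrazol-1-yl, and this assay gives an at least 1.2-fold higher number from compound 2 to compound 4 (0.07 log units; that floor lies within the scatter). The true size of this step stays unread, because compound 2 carries a limit and not a number: the limit of < 10 mL/min/kg in this assay, at which 1 of the 4 values shown sits. The floor alone neither shows nor excludes a real rise at this position.

Methyl and trifluoromethyl leave together here, so their separate shares stay open. The compounds shown also leave open how 4-chloro-1H-pyrazol-1-yl would behave at this place.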